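Swapping the dihydroxyphenyl of compound 2 for a non-aromatic ring

The source may report more compounds than this note shows. Statements on the series, on what has been measured and on what is new or still open speak of the compounds shown alone.

Measured compounds and values:
compound 1, `Oc1ccc(O)c(-c2cc(-c3ccccc3)nn2-c2ccccc2)c1`: 75300 nM
compound 2, `Oc1ccc(O)c(-c2cc(-c3ccc(Cl)cc3)nn2-c2ccccc2)c1`: 60400 nM
compound 3, `CC(=O)NS(=O)(=O)c1ccc(-n2nc(-c3ccc(Cl)cc3)cc2-c2cc(O)ccc2O)cc1`: 81200 nM

In a functional assay on cells (Cancer cell lines, Homo sapiens) for cytotoxicity, read by sulforhodamine B assay, with a stated time of 48 h (a higher number here means a weaker inhibitor of growth, a lower number a stronger inhibitor of growth), compound 2 gives the lowest of the three numbers, but its neighbours stand close: a 1.2-fold lower number from compound 1 to compound 2 (0.10 log units; within the scatter) and a 1.3-fold higher number from compound 2 to compound 3 (0.13 log units; within the scatter) are both within the scatter, so none of the three can be called stronger or weaker than another.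

Compound 4, `O=C1C=CC(=O)C(c2cc(-c3ccc(Cl)cc3)nn2-c2ccccc2)=C1`, is not yet measured. It differs from compound 2 in one place: a group of 8 heavy atoms (6 carbon, 2 oxygen; one six-membered non-aromatic ring of carbon only) in place of a group of 8 heavy atoms (6 carbon, 2 oxygen; one six-membered aromatic ring of carbon only), on an aromatic carbon. The two measured steps concern other positions, the chloro on one outer ring and the acetylsulfamoyl on another, and neither bears on this change. There is nothing here to tell how much the loss of the two hydroxyls and the aromatic ring matters. For the measured compounds named here, with no step to lean on, the expectation is a number close to that of compound 2, with a wide range to allow for an unknown effect.

The estimate for compound 4 in this assay is 50000 nM, ranging from 10000 nM to 200000 nM. The expected step is a 1.2-fold lower number from compound 2 to compound 4 (0.08 log units; within the scatter), not clearly beyond the scatter.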

Compound 4, concentration for total growth inhibition: 81700 nM
The estimate for compound 4 lay 1.6-fold (0.21 log units) below the measured number; measured number inside the range.
By their numbers in this assay, from the lowest: compounds 2, 1, 3 and 4 (each within the scatter of the next).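

In this assay the exchange of the 2,5-dihydroxyphenyl for the non-aromatic ring gives a 1.4-fold higher number from compound 2 to compound 4 (0.13 log units; within the scatter), even though the entering group has no hydrogen-bond donors and its ring is no longer aromatic. For the compounds shown here, this is the first view of this position on the shared core, since the earlier steps concerned other places, and here the numbers of the two compounds cannot be told apart. No measurement of any property of these two groups accompanies the result, so the data offer no explanation for it.

What the compounds shown leave open is whether any other group here, such as an amine or a carboxylic acid, would move the number beyond the scatter. Also open, on these data alone, is how the non-aromatic ring behaves alongside the acetylsulfamoyl group of compound 3.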